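Replacing 4-methoxyphenyl with 2-nitrophenyl in a small series

This account rests on a few compounds, and the source may have more. Where it says the series, first, only, none or still open, it means among the compounds named here.

In a functional assay on HeLa cells (Homo sapiens) for cytotoxicity, read by MTT assay, with a stated time of 24 h (a higher number here means a weaker inhibitor, a lower number a stronger inhibitor), compound 1 (`C/C(=N\NC(=O)/C(C#N)=C/c1ccccc1)c1c(O)c2ccc(O)cc2oc1=O`) gives 15800 nM and compound 2 (`COc1ccc(/C=C(\C#N)C(=O)N/N=C(\C)c2c(O)c3ccc(O)cc3oc2=O)cc1`) gives 7850 nM on the same core. For the measured compounds named here, those two stand level, since the step is a 2.0-fold lower number from compound 1 to compound 2 (0.30 log units; within the scatter) and that is the only step measured at a single place. Compound 3 (`COc1cc(/C=C(\C#N)C(=O)N/N=C(\C)c2c(O)c3ccc(O)cc3oc2=O)cc(OC)c1OC`) gives 18500 nM as a number higher than that of compound 2 by more than the scatter. Compound 4 (`C/C(=N\NC(=O)/C(C#N)=C/c1ccccc1[N+](=O)[O-])c1c(O)c2ccc(O)cc2oc1=O`) takes 2-nitrophenyl in place of 4-methoxyphenyl on a double-bonded chain carbon bound to a double-bonded chain carbon, and the count runs 2-nitrophenyl in place of 4-methoxyphenyl on a double-bonded chain carbon bound to a double-bonded chain carbon for this change. Going by the values given here, removing the methoxy partly reverses the step above, which stayed within the scatter, but no measured compound carries a nitro group. A step beyond the scatter in this assay is therefore not expected, with a slightly higher number as the tentative direction. The expected move is a 1.5-fold higher number from compound 2 to compound 4 (0.18 log units; within the scatter) and it remains uncertain. For compound 4 the estimate is 12000 nM with an expected range of 5000 nM to 28000 nM for repeated measurements.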

Compound 4, half-maximal inhibitory concentration: 10300 nM
Beside the measured number, compound 4's estimate is 1.2-fold (0.07 log units) above it, and the stated range covers the measured number.
By their numbers in this assay, from the lowest: compounds 2, 4, 1 and 3 (each within the scatter of the next, the first and the last beyond it).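

In this assay the exchange of 4-methoxyphenyl for 2-nitrophenyl on a double-bonded chain carbon bound to a double-bonded chain carbon gives a 1.3-fold higher number from compound 2 to compound 4 (0.12 log units; within the scatter), so compound 4 stands level with compound 2. Adding the nitro group to the plain phenyl ring gives a 1.5-fold lower number from compound 1 to compound 4 (0.19 log units; within the scatter), so compound 4 also stands level with compound 1, and neither the methoxy nor the nitro group shifts the number beyond the scatter at this place. No available evidence accounts for this level reading. The compounds shown leave open whether an amine or a carboxylic acid on the same phenyl ring would shift the number beyond the scatter. They also leave open whether 4-nitrophenyl would read the same as 2-nitrophenyl.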